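Series notes: swapping the aryl group of compound 2

The compounds below may be only part of what the source reports. "The series", "measured", "known", "first", "only" and "open" are said of these compounds alone.

Measured so far:
compound 1 `CC1=CC[C@H](C(C)(C)N=C=S)CC1`: > 100000 nM
compound 2 `COc1ccc(/C=N/NC(=S)NC(C)(C)[C@H]2CC=C(C)CC2)cc1`: 29600 nM
compound 3 `CC1=CC[C@H](C(C)(C)NC(=S)N/N=C/c2ccc(N(C)C)cc2)CC1`: > 100000 nM

Among the measured compounds shown here, in a functional assay on 786-0 cells (Homo sapiens) for inhibition, read by sulforhodamine B assay, with a stated time of 48 h (a higher number here means a weaker inhibitor of growth, a lower number a stronger inhibitor of growth), compound 2 gives 29600 nM, the only number among the three values shown. For compound 1 the value > 100000 nM is a limit of the assay and not a number. For compound 3 the value > 100000 nM is likewise a limit. For the measured compounds named here, the one readable step is an at least 3.3-fold higher number from compound 2 to compound 3 (0.52 log units; beyond the scatter), a change on the aromatic ring that sits on the carbon with a double bond to nitrogen.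

Compound 4 `CC1=CC[C@H](C(C)(C)NC(=S)N/N=C/c2ccccc2Cl)CC1` differs from compound 2 by 2-chlorophenyl in place of 4-methoxyphenyl on a carbon with a double bond to nitrogen. Going by the values given here, no measured step exchanges the whole aryl group, so the step from compound 2 to compound 3 bears on it only as a sign that altering this ring moved the number upward beyond the scatter. A modest weakening, or no change beyond the scatter, is therefore expected, and a limit rather than a number remains a real possibility because of the limit of > 100000 nM in this assay, at which 2 of the 3 values shown sit. For compound 4 the estimate in this assay is 50000 nM, within 15000 nM to 150000 nM. That estimate corresponds to an expected step of a 1.7-fold higher number from compound 2 to compound 4 (0.23 log units; within the scatter).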

Compound 4, concentration for total growth inhibition: > 100000 nM
Compound 4: a limit, no number; the forecaster's own chance of this, stated with the estimate: 40%; at least 2.0-fold (0.30 log units) between middle value and limit.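

In this assay, among the compounds shown here, 2-chlorophenyl in place of 4-methoxyphenyl on a carbon with a double bond to nitrogen gives an at least 3.3-fold higher number from compound 2 to compound 4 (0.52 log units; beyond the scatter); this step exchanges the whole aryl group, whereas the earlier step changed only one group on the aromatic ring. For compound 4 the value > 100000 nM is a limit of the assay and not a number. Of the three aryl groups shown, only 4-methoxyphenyl gives a number, so the sensitivity of this position now rests on two different replacements rather than one, and how far either lies from compound 2 stays unknown because the readings stop at the same point: the limit of > 100000 nM in this assay, at which 3 of the 4 values shown sit.

For the compounds shown here, compound 3 and compound 4 cannot be ranked against each other, and no other step among the limit values can be read. On these data alone, compound 4 changes both the group on the ring and its place, so these compounds do not separate the loss of methoxy from the arrival of chlorine, and whether a hydroxyl or an ethoxy group on the aromatic ring would keep a number stays open.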